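Working notes: cyano in place of fluoro

This account rests on a few compounds, and the source may have more. Where it says the series, first, only, none or still open, it means among the compounds named here.

Measured in a functional assay on SMMC-7721 cells (Homo sapiens) for inhibition, read by MTT assay, with a stated time of 48 h; on this read-out higher numbers stand for weaker inhibition and lower numbers for stronger inhibition:
- compound 1 `CN(c1ncccc1CNc1nc(Nc2ccc3c(c2)CC(=O)N3)nc2[nH]ccc12)S(C)(=O)=O`: 52800 nM
- compound 2 `Cc1c[nH]c2nc(Nc3ccc4c(c3)CC(=O)N4)nc(NCc3cccnc3N(C)S(C)(=O)=O)c12`: 18700 nM
- compound 3 `CN(c1ncccc1CNc1nc(Nc2ccc3c(c2)CC(=O)N3)nc2[nH]cc(F)c12)S(C)(=O)=O`: 73200 nM

Compound 3 sits in the upper pair of numbers, and two measured steps reach it: a 1.4-fold higher number from compound 1 to compound 3 (0.14 log units; within the scatter) and a 3.9-fold higher number from compound 2 to compound 3 (0.59 log units; beyond the scatter). Compound 4 `CN(c1ncccc1CNc1nc(Nc2ccc3c(c2)CC(=O)N3)nc2[nH]cc(C#N)c12)S(C)(=O)=O` differs by cyano in place of fluoro on an aromatic carbon. The remaining measured step at such a carbon is a 2.8-fold lower number from compound 1 to compound 2 (0.45 log units; beyond the scatter), so the measured changes range from within the scatter to modest. Within the data shown here, no cyano compound has been measured yet. No step beyond the scatter is expected in this assay, and the estimated step is a 1.5-fold lower number from compound 3 to compound 4 (0.17 log units; within the scatter). Compound 4 is expected at 50000 nM, with an estimated range of 18000 nM to 130000 nM.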

Compound 4, half-maximal inhibitory concentration: > 100000 nM
Compound 4: a limit, no number; the forecaster's own chance of this, stated with the estimate: 10%; middle value at least 2.0-fold (0.30 log units) from the limit.
By their numbers in this assay, from the lowest: compound 2; then compounds 1 and 3 (each within the scatter of the next). At a limit, above all of these: compound 4.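

In this assay compound 4 stands at a limit and not at a number: the limit of > 100000 nM in this assay, at which 1 of the 4 values shown sits. At this aromatic carbon, the floors of an at least 1.3-fold higher number from compound 3 to compound 4 (0.13 log units; that floor lies within the scatter) and an at least 1.8-fold higher number from compound 1 to compound 4 (0.27 log units; that floor lies within the scatter) do not separate cyano from fluoro or hydrogen. Among these compounds, only an at least 5.3-fold higher number from compound 2 to compound 4 (0.72 log units; beyond the scatter) passes beyond the scatter, so methyl remains the one group here set apart from the others, on the side of stronger inhibition.

As far as these compounds go, how far cyano lies past the limit remains unknown. Whether an ethyl group or an amine at this carbon would match methyl is open.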